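From Trifluorophenyl to Tetrafluorophenyl on the Shared Core

This account rests on a few compounds, and the source may have more. Where it says the series, first, only, none or still open, it means among the compounds named here.

In a functional assay on Jurkat cells (Homo sapiens) (on this read-out higher numbers stand for weaker inhibition and lower numbers for stronger inhibition), compound 1 `CC(C)[C@H](NC(=O)COc1cccc2ccccc12)C(=O)N[C@@H](CC(=O)O)C(=O)COc1ccccc1`, with a plain phenyl on the oxygen, gives 14000 nM. Compound 3 `CC(C)[C@H](NC(=O)COc1cccc2ccccc12)C(=O)N[C@@H](CC(=O)O)C(=O)COc1cc(F)c(F)cc1F`, which carries 2,4,5-trifluorophenyl there, gives 39300 nM, the higher of the two exact numbers in the series. The change between them is a 2.8-fold higher number from compound 1 to compound 3 (0.45 log units; beyond the scatter).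

Compound 2 `CC(C)[C@H](NC(=O)COc1cccc2ccccc12)C(=O)N[C@@H](CC(=O)O)C(=O)COc1ccc(F)cc1`, with 4-fluorophenyl, is reported only as a limit of this assay, > 100000 nM. This gives an at least 7.1-fold higher number from compound 1 to compound 2 (0.85 log units; beyond the scatter), followed by an at least 2.5-fold lower number from compound 2 to compound 3 (0.40 log units; beyond the scatter).

Compound 4 `CC(C)[C@H](NC(=O)COc1cccc2ccccc12)C(=O)N[C@@H](CC(=O)O)C(=O)COc1c(F)c(F)cc(F)c1F` differs from compound 3 by one change, (2,3,5,6-tetrafluorophenyl in place of 2,4,5-trifluorophenyl on an oxygen on a saturated carbon). Fluorine count alone does not order the series: the step to compound 3 improves on compound 2, yet compound 1, with no fluorine, has the lowest exact number. Both fluorinated groups measured so far have a fluorine numbered 4 in their names and give higher numbers than compound 1, as an at least 7.1-fold higher number from compound 1 to compound 2 (0.85 log units; beyond the scatter) and a 2.8-fold higher number from compound 1 to compound 3 (0.45 log units; beyond the scatter) show. Within the data shown here, the 2,3,5,6-tetrafluorophenyl name has no such number, so a partial return towards compound 1 seems plausible, though only three compounds support this.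

The expected change is modest and towards stronger inhibition, a 3.9-fold lower number from compound 3 to compound 4 (0.59 log units; beyond the scatter). For compound 4 the estimated value is 10000 nM, with an expected range from 1000 nM to 60000 nM.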

Compound 4, half-maximal inhibitory concentration: 4500 nM
Estimate against measurement, compound 4: 2.2-fold (0.35 log units) above; low and high end bracket the measured number.
By their numbers in this assay, from the lowest: compound 4; then compound 1; then compound 3. At a limit, above all of these: compound 2.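

In this assay, a fluorinated group on this oxygen now gives a lower number than plain phenyl, which neither earlier fluorinated group did, with a 3.1-fold lower number from compound 1 to compound 4 (0.49 log units; beyond the scatter). The change from 2,4,5-trifluorophenyl to 2,3,5,6-tetrafluorophenyl gives an 8.7-fold lower number from compound 3 to compound 4 (0.94 log units; beyond the scatter), and fluorine count still does not order the series, as compound 1, with no fluorine, falls between compound 4 and compound 3. The comparison with 4-fluorophenyl gives an at least 22-fold lower number from compound 2 to compound 4 (1.34 log units; beyond the scatter), a step read against a limit of the assay and not against a number: the limit of > 100000 nM in this assay, at which 1 of the 4 values shown sits.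

The compounds shown leave open whether the lower number of compound 4 goes with the added fluorine or with the loss of the fluorine numbered 4 in the name of the trifluorophenyl group, as both differ together from compound 3 to compound 4. As far as these compounds go, it also remains open whether pentafluorophenyl or a chlorophenyl on the same oxygen would give a number nearer to that of compound 4 or to the limit of compound 2.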